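The source may report more compounds than this note shows. Statements on the series, on what has been measured and on what is new or still open speak of the compounds shown alone.

Working notes on the series, read in an assay on HEK293 cells for activation of Kir3.1/Kir3.2 (Homo sapiens), read by thallium flux; on this read-out higher numbers stand for an effect only at larger amounts of compound and lower numbers for an effect already at smaller amounts.

Three compounds carry numbers. Compound 1 `Cc1cc(NC(=S)Cn2nnc(-c3ccccc3)n2)n(C2CCCCC2)n1` gives 623 nM in this assay. Compound 2 `Cc1cc(NC(=O)Cn2nnc(-c3ccccc3)n2)n(C(C)C)n1` gives 556 nM in this assay. Compound 3 `O=C(Cn1nnc(-c2ccccc2)n1)Nc1cc(C2CC2)nn1C1CCCCC1` gives 271 nM in this assay. On these three numbers compound 2 stands second highest: its gap to compound 1 lies within the scatter, so the two cannot be ordered, while compound 3 sits beyond the scatter on the lower side.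

Compound 4 `Cc1cc(NC(=O)Cn2nnc(-c3ccccc3)n2)n(Cc2ccccc2)n1` is not yet measured. Relative to compound 2 the change is benzyl in place of isopropyl on an aromatic nitrogen. Among the measured compounds shown here, no pair of measured compounds differs in one place only, so no step isolates this kind of change; compound 1 and compound 3 differ from compound 2 in more than one respect each, and their numbers cannot be read as a guide for the aromatic-nitrogen substituent alone. With nothing in the measured set pointing either way, the step of a 1.2-fold lower number from compound 2 to compound 4 (0.09 log units; within the scatter) is expected to stay within the scatter. Compound 4 is therefore estimated at 450 nM, with a range from 150 nM to 1500 nM.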

Compound 4, half-maximal effective concentration: 495 nM
Compound 4: the middle estimate sits 1.1-fold (0.04 log units) below what was measured; the range from low to high includes it.
By their numbers in this assay, from the lowest: compounds 3, 4, 2 and 1 (each within the scatter of the next, the first and the last beyond it).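

Benzyl in place of isopropyl on this aromatic nitrogen gives a 1.1-fold lower number from compound 2 to compound 4 (0.05 log units; within the scatter) in this assay, the only step in the set that isolates a single place. Among the compounds shown here, at this position, next to the ring nitrogen and next to the ring atom that bears a large group, the exchange of a small open group for one carrying a six-membered aromatic ring therefore leaves the number within the scatter, a reading that the earlier compounds could not give. No measurement on these compounds bears on why the two groups read alike.

On these data alone, whether a chain ending in an amine or a carboxylic acid on this nitrogen would also stay within the scatter of compound 2 remains open. Also open, as far as these compounds go, is whether substituents on the benzyl ring, such as a methoxy group or a fluorine atom, would move the number beyond the scatter.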